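A few compounds are considered here, and "the series" means these few. Any claim that something is new, unique, unknown or untested is made for them only; others in the source may bear on it.

Compound 1 `COc1cc(-c2nnc(SCC(=O)c3ccccc3)n2N)cc(OC)c1OC`: 7800 nM in a functional assay on HepG2 cells (Homo sapiens) for antiproliferative activity, read by MTT assay, with a stated time of 48 h; on this read-out lower numbers stand for stronger inhibition and higher numbers for weaker inhibition.
Compound 2 `COc1cc(-c2nnc(SCC(=O)c3ccc(Cl)cc3)n2N)cc(OC)c1OC`: > 100000 nM in this assay, which is a limit of the assay rather than a number.
Compound 3 `COc1cc(-c2nnc(SCC(=O)c3cccc(Br)c3)n2N)cc(OC)c1OC`: 56000 nM in this assay.

Among the numbers shown, compound 3 holds the highest; its nearest neighbour is compound 1, separated by a 7.2-fold higher number from compound 1 to compound 3 (0.86 log units; beyond the scatter). Compound 4 `COc1cc(-c2nnc(SCC(=O)c3ccccc3F)n2N)cc(OC)c1OC` differs from compound 3 by 2-fluorophenyl in place of 3-bromophenyl on a carbonyl carbon. Within the data shown here, the steps that bear on this change are an at least 12-fold higher number from compound 1 to compound 2 (1.10 log units; beyond the scatter), a 7.2-fold higher number from compound 1 to compound 3 (0.86 log units; beyond the scatter) and an at least 1.7-fold lower number from compound 2 to compound 3 (0.25 log units; that floor lies within the scatter): a halogen added to the unsubstituted phenyl of compound 1 raised the number each time, whereas the exchange of one halogenated phenyl for another stayed within the scatter. No fluorine-bearing phenyl has been measured. Compound 4 is therefore estimated at 20000 nM in this assay, between 5000 nM and 100000 nM, an expected step of a 2.8-fold lower number from compound 3 to compound 4 (0.45 log units; beyond the scatter).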

Compound 4, half-maximal inhibitory concentration: 22600 nM
Compound 4: the middle estimate sits 1.1-fold (0.05 log units) below what was measured, within the range that was stated.
By their numbers in this assay, from the lowest: compound 1; then compound 4; then compound 3. At a limit, above all of these: compound 2.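

Fluoro in place of hydrogen also raises the number in this assay with a 2.9-fold higher number from compound 1 to compound 4 (0.46 log units; beyond the scatter) so all three halogenated phenyls shown sit above the unsubstituted phenyl. Exchanging one halogenated phenyl for another can also move the number beyond the scatter, with a 2.5-fold lower number from compound 3 to compound 4 (0.39 log units; beyond the scatter) and an at least 4.4-fold lower number from compound 2 to compound 4 (0.64 log units; beyond the scatter) the second of these resting on a limit rather than a number: the limit of > 100000 nM in this assay, at which 1 of the 4 values shown sits.

On these data alone, whether the halogen itself or its place on the phenyl sets these numbers stays open, as does how an amine or a carboxylic acid on that phenyl would read.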